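The source may report more compounds than this note shows. Statements on the series, on what has been measured and on what is new or still open speak of the compounds shown alone.

In an ADME assay on L1210/0 cells (Mus musculus) for cytotoxicity, with a stated time of 48 h (on this read-out higher numbers stand for weaker inhibition and lower numbers for stronger inhibition), compound 1 `OC[C@H]1C[C@@H](Cn2cnc3c(-c4ccc(Cl)cc4)ncnc32)c2ccccc21` gives 8440 nM. Compound 3 `O=C1O/C(=C\Cn2ccc(=O)[nH]c2=O)C(OCc2ccccc2)=C1OCc1ccccc1` gives 12900 nM, and these two values lie within the scatter of each other, so neither can be ranked ahead of the other. Compound 2 `O=c1[nH]cnc2c1nnn2C1C[C@H](CO)[C@@H](CO)[C@@H]1CO` is reported only as a limit of the assay, > 200000 nM. Compound 1 therefore shares the low end of the numbers shown with compound 3.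

Compound 4 `COc1ncnc2c1ncn2C[C@@H]1C[C@H](CO)c2ccccc21` keeps the core of compound 1 but carries methoxy in place of 4-chlorophenyl on an aromatic carbon. Going by the values given here, no step between measured compounds gives a size for this change, so any expectation remains tentative. A move towards higher numbers in this assay, beyond the scatter, is expected, and the estimated step is a 7.1-fold higher number from compound 1 to compound 4 (0.85 log units; beyond the scatter). Compound 4 is estimated at 60000 nM, with an expected range of 15000 nM to 190000 nM.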

Compound 4, half-maximal inhibitory concentration: > 200000 nM
Compound 4: a limit, no number; the forecaster's own chance of this, stated with the estimate: 35%; at least 3.3-fold (0.52 log units) between middle value and limit.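

In this assay, going by these compounds alone, this is the first step that gives a size for a change at this aromatic carbon: methoxy in place of 4-chlorophenyl on the shared core gives an at least 23-fold higher number from compound 1 to compound 4 (1.37 log units; beyond the scatter), so the read-out depends strongly on what this carbon carries. Only the lower bound of that step is known, as the value of compound 4 is a limit of the assay and not a number: the limit of > 200000 nM in this assay, at which 2 of the 4 values shown sit. The change removes a six-membered aromatic ring of carbon only, together with its chlorine, and brings in a group with no ring and one hydrogen-bond acceptor, so this single step cannot separate these differences.

Going by these compounds, whether a plain phenyl without the chlorine, or an amine on this carbon, would stay close to compound 1 remains open. On these data alone, how far compound 4 lies past the limit also remains unknown.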